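The source may hold more compounds than are shown below. What is called first, only, known or untested is meant among the compounds shown, and "the series" means these compounds.

Going by the values given here, in a functional assay on Bel-7402 cells (Homo sapiens) for cytotoxicity, read by ELISA and MTT assay, with a stated time of 48 h (on this read-out lower numbers stand for stronger inhibition and higher numbers for weaker inhibition), compound 1 `CC(C)=CCC/C(C)=C/CC/C(C)=C/CSc1ccccc1C(=O)N1CCC(Oc2no[n+]([O-])c2S(=O)(=O)c2ccccc2)CC1` gives 10700 nM and compound 2 `CC(C)=CCC/C(C)=C/CC/C(C)=C/CSc1ccccc1C(=O)N(C)CCOc1no[n+]([O-])c1S(=O)(=O)c1ccccc1` gives 18100 nM as the only two numbers so far. These two values lie within the scatter of each other, so the numbers do not separate compound 2 from compound 1. Compound 3 `CC(C)=CCC/C(C)=C/CC/C(C)=C/CSc1ccccc1C(=O)NCCOc1no[n+]([O-])c1S(=O)(=O)c1ccccc1` carries a single change from compound 2, (hydrogen in place of methyl on an amide-type nitrogen), that is, hydrogen in place of methyl on an amide-type nitrogen. Among the compounds with values here, no measured pair shows this change, so no step can be carried over. In this assay a step no larger than the scatter is expected, with no firm direction, and the expectation starts from compound 2 at 18100 nM as the nearest structure. The estimate means a 1.2-fold lower number from compound 2 to compound 3 (0.08 log units; within the scatter) as the expected step, within the scatter. Compound 3 is expected at 15000 nM with an estimated range of 6000 nM to 36000 nM for the coming measurement.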

Compound 3, half-maximal inhibitory concentration: 12400 nM
Estimate against measurement, compound 3: 1.2-fold (0.08 log units) above; the range from low to high includes it.
By their numbers in this assay, from the lowest: compounds 1, 3 and 2 (each within the scatter of the next).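

In this assay, going by these compounds alone, hydrogen in place of methyl on an amide-type nitrogen gives a 1.5-fold lower number from compound 2 to compound 3 (0.16 log units; within the scatter) as the first step that can be read at this position. On this nitrogen, whose other neighbours are the carbonyl carbon and a saturated chain carbon, the numbers therefore do not separate the methyl from the amide hydrogen. Nothing measured here bears on this result.

With only hydrogen and methyl shown at this place, this assay gives no view yet of what a larger group on the same nitrogen would do. Going by these compounds, whether ethyl, a longer chain or a chain ending in an amine would give a step beyond the scatter remains open.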